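Longer acid chains on a triphenylpyrazole core

The compounds below may be only part of what the source reports. "The series", "measured", "known", "first", "only" and "open" are said of these compounds alone.

Compound 2, with the structure `O=C(O)CCCCCCCn1nc(-c2ccccc2)c(-c2ccccc2)c1-c1ccccc1`, gives 3400 nM in a functional assay for inhibition, with Homo sapiens as the target; on this read-out lower numbers stand for stronger inhibition and higher numbers for weaker inhibition. Among the numbers shown it stands as the only one, since the other measured compound reached no number. Compound 1, `O=C(O)CCCCCn1nc(-c2ccccc2)c(-c2ccccc2)c1-c1ccccc1`, in this assay gives only > 78000 nM, which is a limit of the assay and not a number. Within the data shown here, the one step available, an at least 22-fold lower number from compound 1 to compound 2 (1.36 log units; beyond the scatter), is large, and its starting point is the limit of > 78000 nM in this assay, at which 1 of the 2 values shown sits, so its true size is unknown beyond the limit.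

Compound 3, `O=C(O)CCCCCCCCCn1nc(-c2ccccc2)c(-c2ccccc2)c1-c1ccccc1`, has not yet been measured. Its difference from compound 2 is 2-carboxyethyl in place of carboxy on a saturated chain carbon, seven bonds along the chain from an aromatic nitrogen. This is the same kind of change as in the measured step, taken one stage further along the chain. Among the measured compounds shown here, with only one step to go on, and that step beginning at a limit, a continued but smaller gain is a reasonable expectation rather than a repeat of the large step. Compound 3 is therefore expected to give an estimate of 1500 nM in this assay, within 400 nM to 6000 nM, meaning an expected step of a 2.3-fold lower number from compound 2 to compound 3 (0.36 log units; beyond the scatter).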

Compound 3, half-maximal inhibitory concentration: 5500 nM
Estimate against measurement, compound 3: 3.7-fold (0.56 log units) below; the measured number falls inside the stated range.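

Extending the chain again, with 2-carboxyethyl in place of carboxy on a saturated chain carbon, seven bonds along the chain from an aromatic nitrogen, does not carry the earlier gain forward: in this assay the result is a 1.6-fold higher number from compound 2 to compound 3 (0.21 log units; within the scatter), so this change leaves compound 2 and compound 3 indistinguishable. The large difference therefore separates compound 1 from both longer acids, rather than growing steadily with each extension, and the comparison across the whole change is an at least 14-fold lower number from compound 1 to compound 3 (1.15 log units; beyond the scatter). Compound 1 stands at a limit of the assay and not at a number, so the true size of that large difference stays unknown: the limit of > 78000 nM in this assay, at which 1 of the 3 values shown sits.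

The compounds shown leave open how a chain of intermediate length would behave, and whether a still longer chain would hold this level or lose it. They also leave open whether an amide or a tetrazole in place of the carboxy group would keep any inhibition in this assay.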